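From 4-fluorobenzyl to 3-bromobenzyl on a shared core

The source may hold more compounds than are shown below. What is called first, only, known or untested is meant among the compounds shown, and "the series" means these compounds.

For the measured compounds named here, in a functional assay on BV-2 cells (Mus musculus), read by Griess assay, with a stated time of 24 h (a lower number here means a stronger inhibitor, a higher number a weaker inhibitor), compound 2 `O=C1C=CC2(C=C1)OCC(Cc1ccc(F)cc1)C(=O)N2c1ccccc1` gives 400 nM, the lower of the two numbers measured so far. Going by the values given here, the only other measured compound, compound 1 `C=CCC1COC2(C=CC(=O)C=C2)N(c2ccccc2)C1=O`, gives 1030 nM.

The next compound, compound 3 `O=C1C=CC2(C=C1)OCC(Cc1cccc(Br)c1)C(=O)N2c1ccccc1`, keeps the shared core and changes one group: 3-bromophenyl in place of 4-fluorophenyl on a saturated chain carbon bound to a saturated ring carbon. In words, 3-bromophenyl stands in place of 4-fluorophenyl on a saturated chain carbon bound to a saturated ring carbon.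

Among the compounds with values here, only one measured step bears on this change, at the same place: a 2.6-fold lower number from compound 1 to compound 2 (0.41 log units; beyond the scatter), with 4-fluorophenyl in place of vinyl. In that step a vinyl group left, whereas here one six-membered aromatic ring of carbon only leaves and another enters. A smaller move than a 2.6-fold lower number from compound 1 to compound 2 (0.41 log units; beyond the scatter) is therefore expected. Within the data shown here, no measured pair shows what bromine in place of fluorine does here, so no direction can be favoured firmly.

The estimate means a 1.1-fold lower number from compound 2 to compound 3 (0.03 log units; within the scatter), an expected change that may not exceed the scatter. For compound 3, the expected value is 370 nM, with an estimated range from 140 nM to 950 nM.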

Compound 3, half-maximal inhibitory concentration: 540 nM
Compound 3: the middle estimate sits 1.5-fold (0.16 log units) below what was measured, and the stated range covers the measured number.
By their numbers in this assay, from the lowest: compounds 2, 3 and 1 (each within the scatter of the next, the first and the last beyond it).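

In this assay, the exchange of 4-fluorobenzyl for 3-bromobenzyl on the shared core reads as a 1.4-fold higher number from compound 2 to compound 3 (0.13 log units; within the scatter), so at this position the two substituted rings are not told apart by this measurement. The other new step, a 1.9-fold lower number from compound 1 to compound 3 (0.28 log units; within the scatter), also stays within the scatter, so 3-bromophenyl in place of vinyl does not repeat the step beyond the scatter seen with 4-fluorophenyl in place of vinyl, even though the two end compounds of the series, 1 and 2, remain apart. Nothing measured here offers an explanation for these readings.

From the compounds shown here alone, what 4-bromophenyl or 3-fluorophenyl would give at this place remains open, and without them the choice of halogen cannot be separated from where it stands on the ring. Also open, going by these compounds, is how an amine, a carboxylic acid or a longer chain on the saturated chain carbon would compare with the three numbers now in hand.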